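Replacing a Methoxy Group: Expected Lipophilicity of Compound 4

The compounds below may be only part of what the source reports. "The series", "measured", "known", "first", "only" and "open" are said of these compounds alone.

Three compounds share a core and differ only in the side chain on a saturated chain carbon bound to a saturated ring carbon. In a physicochemical assay for lipophilicity, read by HPLC, measured as octanol-water partition (a lower number here means a more polar compound, a higher number a more lipophilic compound), compound 1 `O=C1O[C@@H](CN2CCC(c3ccc(F)cc3)CC2)CN1c1ccc(-n2cc(-c3ccccn3)cn2)c(F)c1` gives 5.78, compound 2 `COC[C@H]1CN(c2ccc(-n3cc(-c4ccccn4)cn3)c(F)c2)C(=O)O1` gives 2.18, and compound 3 `O=C1O[C@@H](Cn2ccnn2)CN1c1ccc(-n2cc(-c3ccccn3)cn2)c(F)c1` gives 2. Compound 2 thus stands second highest of the three: compound 3 is nearest, with a number 0.18 log units lower from compound 2 to compound 3 (within the scatter), while compound 1 lies far higher. Compound 4 `O=C1O[C@@H](CNC(=O)C(F)(F)F)CN1c1ccc(-n2cc(-c3ccccn3)cn2)c(F)c1` is not yet measured in this assay. It differs from compound 2 as follows: ((trifluoromethyl)carbonyl)amino in place of methoxy on a saturated chain carbon bound to a saturated ring carbon.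

Going by the values given here, only one measured step bears on this change, the one from compound 2 to compound 3, in which a 1H-1,2,3-triazol-1-yl replaced the methoxy at the same place and the number barely moved, as a number 0.18 log units lower from compound 2 to compound 3 (within the scatter) shows. The large gap between compound 1 and compound 2 involves a different and much bigger group and offers no direct guide. The ((trifluoromethyl)carbonyl)amino group brings more heavy atoms and one hydrogen-bond donor, so a small rise, if any, is expected, with a number 0.22 log units higher from compound 2 to compound 4 (within the scatter) most likely within or just beyond the scatter. Compound 4 is therefore estimated at 2.4 in this assay, with a range from 1.8 to 3.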

Compound 4, partition coefficient: >= 1.78
Compound 4: a limit, no number; the forecaster's own chance of this, stated with the estimate: 2%; the middle value does not contradict the limit.
By their numbers in this assay, from the lowest: compounds 3 and 2 (each within the scatter of the next); then compound 1.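

In this assay compound 4 gives >= 1.78, which is a limit of the assay and not a number. Going by these compounds alone, no step from compound 2 or compound 3 to compound 4 can therefore be read. The compounds shown leave open how the number changes when ((trifluoromethyl)carbonyl)amino stands in place of methoxy.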